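The source may hold more compounds than are shown below. What is called first, only, known or untested is meant among the compounds shown, and "the series" means these compounds.

In a functional assay on HCC78 cells (Homo sapiens) for antiproliferative activity, read by MTT assay, with a stated time of 48 h (a higher number here means a weaker inhibitor, a lower number a stronger inhibitor), compound 1 `CC(Oc1ccnc(Nc2cnn(C)c2)c1)c1cccc(C(=O)NCc2cc(C(F)(F)F)cc(C(F)(F)F)c2)c1` gives 9300 nM, compound 2 `Cc1ccc(CNC(=O)c2cccc(C(C)Oc3ccnc(Nc4cn(C)nc4C)c3)c2)cc1` gives 17500 nM, and compound 3 `Cc1ccc(CNC(=O)c2cccc(C(C)Oc3ccnc(NN4CCOCC4)c3)c2)cc1` gives 68300 nM, the highest number of the three. Compound 4 `Cc1ccc(CNC(=O)c2cccc(C(C)Oc3ccnc(Nc4cnn(CC(C)(C)O)c4)c3)c2)cc1` differs from compound 3 by 1-(2-hydroxy-2-methylpropyl)-1H-pyrazol-4-yl in place of morpholin-4-yl on a nitrogen on an aromatic ring. For the measured compounds named here, the one measured step that bears on this is a 3.9-fold higher number from compound 2 to compound 3 (0.59 log units; beyond the scatter), in which a pyrazolyl group on the same nitrogen was exchanged for morpholin-4-yl; compound 4 reverses that direction of change, with a 1-(2-hydroxy-2-methylpropyl) group on the pyrazole instead of methyl groups. A step of about that size back towards a lower number is therefore expected in this assay, namely a 4.3-fold lower number from compound 3 to compound 4 (0.63 log units; beyond the scatter). Compound 4 is estimated at 16000 nM, within a range from 6000 nM to 40000 nM.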

Compound 4, half-maximal inhibitory concentration: 49700 nM
Compound 4: middle estimate off by 3.1-fold (0.49 log units), on the low side; measured number outside the range, above it.
By their numbers in this assay, from the lowest: compounds 1 and 2 (each within the scatter of the next); then compounds 4 and 3 (each within the scatter of the next).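

The pyrazole ring on this nitrogen does not by itself bring the number down: there is a 1.4-fold lower number from compound 3 to compound 4 (0.14 log units; within the scatter), so this pyrazole cannot be told apart from morpholin-4-yl here. For the compounds shown here, what is carried on the pyrazole does matter, since there is a 2.8-fold higher number from compound 2 to compound 4 (0.45 log units; beyond the scatter), the only change being 1-(2-hydroxy-2-methylpropyl)-1H-pyrazol-4-yl in place of 1,3-dimethyl-1H-pyrazol-4-yl.

The compounds shown leave open whether a pyrazole carrying an amine or a carboxylic acid on its chain, or a simple ethyl group, would give a lower or higher number. Nothing measured here explains either step.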